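Swapping a bromo for an acetamidopropynyl chain on the core

The source may hold more compounds than are shown below. What is called first, only, known or untested is meant among the compounds shown, and "the series" means these compounds.

Measured so far, in a functional assay on 1321N1 cells for antagonist activity at P2Y purinoceptor 6 (Homo sapiens), read by fluorescence and calcium flux; a lower number here means a stronger inhibitor, a higher number a weaker inhibitor:
compound 3 `O=[N+]([O-])C1=Cc2cc(Br)ccc2OC1C(F)(F)F` gives 3490 nM
compound 1 `COC(=O)CC(C)(C)CC(=O)NCC#Cc1ccc2c(c1)C=C([N+](=O)[O-])C(C(F)(F)F)O2` gives 5900 nM
compound 2 `CC(C)(C)OC(=O)NCC#Cc1ccc2c(c1)C=C([N+](=O)[O-])C(C(F)(F)F)O2` gives 1200 nM

Compound 3 stands second highest of the three; compound 1 sits within the scatter of it, while compound 2 lies lower, beyond the scatter. Compound 4 `CC(=O)NCC#Cc1ccc2c(c1)C=C([N+](=O)[O-])C(C(F)(F)F)O2` differs from compound 3 in one place: 3-acetamidoprop-1-yn-1-yl in place of bromo on an aromatic carbon. Within the data shown here, no measured step makes this exact change. The only step shown, a 4.9-fold lower number from compound 1 to compound 2 (0.69 log units; beyond the scatter), alters the carbonyl end of a chain that compounds 1 and 2 already carry, so it bears only indirectly: it suggests the chain's carbonyl substituent matters, and compound 4 carries the smallest of them. A modest step downward is therefore expected in this assay, as a 1.7-fold lower number from compound 3 to compound 4 (0.24 log units; within the scatter). Compound 4 is estimated at 2000 nM, with a range of 700 nM to 6000 nM.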

Compound 4, half-maximal inhibitory concentration: 7670 nM
Beside the measured number, compound 4's estimate is 3.8-fold (0.58 log units) below it; measured number outside the range, above it.
By their numbers in this assay, from the lowest: compound 2; then compounds 3, 1 and 4 (each within the scatter of the next, the first and the last beyond it).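

In this assay, the 3-acetamidoprop-1-yn-1-yl chain does not improve on bromo at this aromatic carbon, giving a 2.2-fold higher number from compound 3 to compound 4 (0.34 log units; beyond the scatter). What caps the chain counts more: methyl in place of tert-butoxy gives a 6.4-fold higher number from compound 2 to compound 4 (0.81 log units; beyond the scatter), while a 1.3-fold higher number from compound 1 to compound 4 (0.11 log units; within the scatter) stays within the scatter, so the smallest cap offers no gain over the long one. No evidence here accounts for these differences.

As far as these compounds go, whether a free amine or a carboxylic acid at the chain's end would give a lower number remains open. So does the effect of a longer chain carrying a tert-butoxy carbonyl.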